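Pyrrolidinyl dithiocarbamate analogue: expected antiproliferative read-out

A few compounds are considered here, and "the series" means these few. Any claim that something is new, unique, unknown or untested is made for them only; others in the source may bear on it.

Compound 1 `CC1CCCCN1C(=S)SCc1ccc(C(=O)Nc2ccccc2N)cc1`: 64.4%
Compound 2 `CN(Cc1cccnc1)C(=S)SCc1ccc(C(=O)Nc2ccccc2N)cc1`: 45.9%

In a functional assay on MGC-803 cells (Homo sapiens) for antiproliferative activity, read by CCK-8 assay, with a stated time of 72 h, tested at 2 uM (on this read-out higher numbers stand for a stronger effect at the one concentration tested and lower numbers for a weaker effect), compound 1 gives 64.4%, and compound 2 gives 45.9%. For the measured compounds named here, of the two measured compounds, compound 2 stands lowest; the single measured step runs a number 18.5 percentage points lower from compound 1 to compound 2 (beyond the scatter), which is beyond the scatter and modest in size.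

Compound 3 `Nc1ccccc1NC(=O)c1ccc(CSC(=S)N2CCCC2)cc1` has not yet been measured. It differs from compound 2 in one place: pyrrolidin-1-yl in place of methyl((pyridin-3-yl)methyl)amino on a thiocarbonyl carbon. Going by the values given here, only the step from compound 1 to compound 2 bears on this change, since it also exchanged the group on the thiocarbonyl carbon: 2-methylpiperidin-1-yl, a ring group, gave way to methyl((pyridin-3-yl)methyl)amino, and the number fell by a modest amount. The change to compound 3 runs in the opposite sense, back from methyl((pyridin-3-yl)methyl)amino to a ring group, pyrrolidin-1-yl. A rise of roughly the size seen in a number 18.5 percentage points lower from compound 1 to compound 2 (beyond the scatter) is therefore expected, though pyrrolidin-1-yl is a smaller ring than 2-methylpiperidin-1-yl, so the range is kept wide. Compound 3 is estimated to give 58%, between 40% and 74%. This estimate means an expected step of a number 12.1 percentage points higher from compound 2 to compound 3 (beyond the scatter).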

Compound 3, a percentage reported as inhibition, at one concentration (the size of the read-out at that concentration, not a potency): 27%
Compound 3: middle estimate off by 31 percentage points, on the high side; measured number outside the range, below it.
By their numbers in this assay, from the lowest: compound 3; then compound 2; then compound 1.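

On the thiocarbonyl carbon, having a ring group does not by itself give a high number in this assay: the two ring groups are far apart (the change is a number 37.4 percentage points lower from compound 1 to compound 3 (beyond the scatter)). Compound 3 with pyrrolidin-1-yl also falls short of the open methyl((pyridin-3-yl)methyl)amino group (the change is a number 18.9 percentage points lower from compound 2 to compound 3 (beyond the scatter)), so the earlier ordering of a ring group over this open group holds for compound 1 but is reversed for compound 3, and across these three compounds the read-out depends on which particular group sits at this position rather than on the presence of a ring. Nothing available here accounts for these differences.

The compounds shown leave open whether the gap between the two ring groups follows the ring size or the methyl of 2-methylpiperidin-1-yl, a question that unsubstituted piperidin-1-yl on the same thiocarbonyl carbon would address. They also leave open how morpholin-4-yl or a simple dimethylamino group would stand among these three.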